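The source may report more compounds than this note shows. Statements on the series, on what has been measured and on what is new or still open speak of the compounds shown alone.

Measured so far in a functional assay on BT-549 cells (Homo sapiens) for inhibition, read by sulforhodamine B assay, with a stated time of 48 h; a lower number here means a stronger inhibitor of growth, a higher number a weaker inhibitor of growth:

compound 1 `COc1cc(-c2nn(-c3cccc(NC(=O)Nc4ccc(Cl)c(Cl)c4)c3)cc2-c2ccncc2)ccc1Cl`: 1680 nM
compound 2 `COc1cc(-c2nn(-c3cccc(NC(=O)Nc4cccc(C(F)(F)F)c4)c3)cc2-c2ccncc2)ccc1Cl`: 1250 nM

Compound 2 stands at 1250 nM in this assay and has only compound 1 to be compared with, the two lying within the scatter of each other. Compound 3 `COc1cc(-c2nn(-c3cccc(NC(=O)Nc4ccc(Cl)c(C(F)(F)F)c4)c3)cc2-c2ccncc2)ccc1Cl` differs from compound 2 in one place: chloro in place of hydrogen on an aromatic carbon with chloro in place of hydrogen on an aromatic carbon, giving 4-chloro-3-(trifluoromethyl)phenyl. Among the measured compounds shown here, the one measured step that bears on this is a 1.3-fold lower number from compound 1 to compound 2 (0.13 log units; within the scatter) and it joins 3,4-dichlorophenyl to 3-(trifluoromethyl)phenyl, the two groups whose substituents compound 3 shares. With that step inside the scatter, no shift beyond the scatter is expected. The expected change is a 1.0-fold higher number from compound 2 to compound 3 (0.02 log units; within the scatter) on this estimate. Compound 3 is estimated at 1300 nM with an expected range from 600 nM to 2800 nM in this assay when measured.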

Compound 3, concentration for 50% growth inhibition: 2360 nM
Compound 3: the middle estimate sits 1.8-fold (0.26 log units) below what was measured; the measured number falls inside the stated range.
By their numbers in this assay, from the lowest: compounds 2, 1 and 3 (each within the scatter of the next).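

In this assay, chloro on the aromatic carbon ortho to the trifluoromethyl group and para to a large group gives a 1.9-fold higher number from compound 2 to compound 3 (0.28 log units; within the scatter), so this added chloro brings no shift beyond the scatter. Trifluoromethyl in place of chloro on an aromatic carbon gives a 1.4-fold higher number from compound 1 to compound 3 (0.15 log units; within the scatter), so that exchange also stays inside the scatter, and all three compounds now lie within the scatter of one another. Nothing shown explains these values.

The compounds shown leave open whether any group at this position can move the number beyond the scatter, since they carry only chloro and trifluoromethyl there. As far as these compounds go, a methoxy group, a nitrile, an amine or a carboxylic acid on this ring could answer that, and changes to the shared core remain untested here.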